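This account rests on a few compounds, and the source may have more. Where it says the series, first, only, none or still open, it means among the compounds named here.

Measured compounds:
- compound 1 `O=C(O)c1ccc(Cl)cc1-c1ccc2c(c1)OC[C@H](Cc1ccccc1)[C@H]2O`: 200 nM; 14 nM; 12 nM (3 entries)
- compound 2 `O=C(O)c1ccc(Cl)cc1-c1ccc2c(c1)OC[C@H](Cc1ccc(-c3ccccc3)cc1)[C@H]2O`: 8 nM; 4 nM (2 entries)
- compound 3 `O=C(O)c1ccc(Cl)cc1-c1ccc2c(c1)OC[C@H](Cc1ccc(C(F)(F)F)cc1)[C@H]2O`: 400 nM

Working notes. In an assay on isolated protein for binding affinity to leukotriene B4 receptor (Homo sapiens) (a higher number here means a weaker inhibitor, a lower number a stronger inhibitor), compound 1 gives 200 nM; 14 nM; 12 nM (3 entries); the spread across its entries is wide, as the several entries of compound 1 in this assay, 200 nM; 14 nM; 12 nM (3 entries) shows. Compound 2 gives 8 nM; 4 nM (2 entries), with closer agreement between its entries (the several entries of compound 2 in this assay, 8 nM; 4 nM (2 entries)). Compound 3 gives 400 nM, the highest single number in this assay among the three, and its two further entries carry no single number at all. No step between any two of these compounds is established, so the three values are taken only as they stand.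

Compound 4 `O=C(O)c1ccc(Cl)cc1-c1ccc2c(c1)OC[C@H](Cc1ccc(F)cc1)[C@H]2O` is not yet measured in this assay. It differs from compound 3 by fluoro in place of trifluoromethyl on an aromatic carbon. Since the substituted phenyl of compound 3 gives the highest number shown while the unsubstituted phenyl of compound 1 gives 200 nM; 14 nM; 12 nM (3 entries), a moderate move toward a lower number is expected for compound 4 rather than a change beyond the scatter in the other direction; the expected step is a 2.7-fold lower number from compound 3 to compound 4 (0.43 log units; beyond the scatter). For compound 4 the estimate in this assay is 150 nM, with a range from 30 nM to 600 nM.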

Compound 4, half-maximal inhibitory concentration: 54 nM
Beside the measured number, compound 4's estimate is 2.8-fold (0.44 log units) above it; the measured number falls inside the stated range.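

In this assay, for the compounds shown here, the change from 4-(trifluoromethyl)phenyl to 4-fluorophenyl gives the first readable step: a 7.4-fold lower number from compound 3 to compound 4 (0.87 log units; beyond the scatter). This shows that the number responds to the group on this aromatic carbon, although the step rests on the single number shown for compound 3. No step to compound 1 can be read, and compound 4 at 54 nM lies inside the wide spread of that compound's entries: the several entries of compound 1 in this assay, 200 nM; 14 nM; 12 nM (3 entries)

Going by these compounds, it remains open how a methoxy group, an amine or a carboxylic acid on this aromatic carbon would read in this assay. Also open, on these data alone, is whether other groups carrying a second ring here would reach the numbers of compound 2, 8 nM; 4 nM (2 entries).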